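Moving the Methyl Group on the Sulfonamide Ring

The source may hold more compounds than are shown below. What is called first, only, known or untested is meant among the compounds shown, and "the series" means these compounds.

Compound 1, `O=C(NCc1ccc(CNS(=O)(=O)c2ccc(-c3ccc(F)cc3)cc2)cc1)c1ccc(F)cc1`, gives 100 nM in an assay on MDA-MB-231 cells for binding affinity to C-X-C chemokine receptor type 4 (Homo sapiens), read by fluorescence and microscopy, with stated times of 10 min and 30 min; on this read-out lower numbers stand for an effect already at smaller amounts and higher numbers for an effect only at larger amounts of compound.
Compound 2, `Cc1ccccc1S(=O)(=O)NCc1ccc(CNC(=O)c2ccc(F)cc2)cc1`, gives 100 nM.
Compound 3, `Cc1ccc(S(=O)(=O)NCc2ccc(CNC(=O)c3ccc(F)cn3)cc2)cc1`, gives 1000 nM.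

Compound 2 stands level with compound 1 at the digits shown, and together these two have the lowest numbers of the three. For the measured compounds named here, compound 3 has a far higher number, a gap beyond the usual scatter, but it differs from compound 2 in more than one place, so no single step can be drawn between them.

Compound 4, `Cc1cccc(S(=O)(=O)NCc2ccc(CNC(=O)c3ccc(F)cc3)cc2)c1`, differs from compound 2 in one place only: 3-methylphenyl in place of 2-methylphenyl on a sulfonyl sulfur. The same atoms are present, joined differently. No measured pair isolates this kind of move, so the expected step from compound 2 to compound 4 rests on the small set shown and is uncertain. A modest step, a 1.5-fold higher number from compound 2 to compound 4 (0.18 log units; within the scatter), toward a slightly higher number or none beyond the scatter is expected. Compound 4 is estimated at 150 nM, within a range from 50 nM to 600 nM.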

Compound 4, effective concentration (reported as EC, without a stated level of effect): 1 nM
Beside the measured number, compound 4's estimate is 150-fold (2.18 log units) above it, outside the stated range (below it).
By their numbers in this assay, from the lowest: compound 4; then compounds 1 and 2 (each within the scatter of the next); then compound 3.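

Replacing 2-methylphenyl with 3-methylphenyl on a sulfonyl sulfur gives a 100-fold lower number from compound 2 to compound 4 (2.00 log units; beyond the scatter) in this assay, although no atom is added or removed. This is the first step among these compounds that isolates a single change, and it shows that the number can depend strongly on where one methyl group sits on this ring, not only on which atoms are present. No measurement shown here accounts for the size of this step.

As far as these compounds go, it remains open whether the large step is specific to a methyl group or would also appear with another group at the same ring position, such as a methoxy group, an amine or a carboxylic acid. A longer chain, such as an ethyl or propyl group, in place of the methyl group on the 3-methylphenyl ring is equally unresolved.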